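Compound 2 to compound 4: one added methyl

This account rests on a few compounds, and the source may have more. Where it says the series, first, only, none or still open, it means among the compounds named here.

In a functional assay on A549 cells (Homo sapiens) for cytotoxicity, read by MTT assay, with a stated time of 72 h (a higher number here means a weaker inhibitor, a lower number a stronger inhibitor), compound 1 `COc1ccc(NC(=O)CN2CCN(c3nnc(Cc4ccccc4)c4ccccc34)CC2)cc1OC` gives "not active" (no number reported). Compound 2 `Cc1ccccc1NC(=O)CN1CCN(c2nnc(Cc3ccccc3)c3ccccc23)CC1` gives "not active" (no number reported), so it has no single number and can be placed only alongside compound 1, the other entry without one. For the measured compounds named here, the only number so far belongs to compound 3 `Cc1ccccc1NC(=O)CN1CCN(c2nnc(Cc3ccncc3)c3ccccc23)CC1`, at 43100 nM.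

Compound 4 `Cc1ccc(NC(=O)CN2CCN(c3nnc(Cc4ccccc4)c4ccccc34)CC2)c(C)c1` has not yet been measured. The change methyl in place of hydrogen on an aromatic carbon is methyl in place of hydrogen on an aromatic carbon, meta to a methyl group and para to a large group, taking 2-methylphenyl to 2,4-dimethylphenyl.

Going by the values given here, no measured step gauges such a change. No clear gain in this assay is expected, and any shift in either direction is expected to stay small. The likeliest outcome is that compound 4 matches compound 2 at "not active" (no number reported), with no number reported. If a number is obtained, compound 4 is estimated at 50000 nM, with an expected range of 20000 nM to 100000 nM.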

Compound 4, half-maximal inhibitory concentration: "not active" (no number reported)
Compound 4: no number reported; no gap can be computed for the estimate.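

In this assay compound 2 gives "not active" (no number reported) and compound 4 gives "not active" (no number reported) and so no step can be read between them. No supporting evidence bears on this result. The compounds shown leave open whether the added methyl shifts cytotoxicity at all.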